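The compounds below may be only part of what the source reports. "The series", "measured", "known", "first", "only" and "open" are said of these compounds alone.

Measured in a functional assay on the whole organism (strain Sprague-Dawley) for inhibition, with Rattus norvegicus as the target, with a stated time of 10 min; on this read-out higher numbers stand for an effect only at larger amounts of compound and lower numbers for an effect already at smaller amounts:
Compound 1 `CCOc1ccc(N)cc1-c1ncc(C(=O)O)c(=O)[nH]1`: 1.2 mg/kg
Compound 2 `CCOC(=O)c1cnc(-c2cc(OC)ccc2OCC)[nH]c1=O`: 0.3 mg/kg
Compound 3 `CCOC(=O)c1ccc(OCC)c(-c2ncc(C(=O)OCC)c(=O)[nH]2)c1`: 1 mg/kg

Compound 3, at 1 mg/kg, lies within the scatter of compound 1 and clearly above compound 2. Compound 4 `CCOC(=O)c1cnc(-c2cc(N)ccc2OCC)[nH]c1=O` arises from compound 3 by one change: amino in place of ethoxycarbonyl on an aromatic carbon. For the measured compounds named here, the only measured step at this place is a 3.3-fold higher number from compound 2 to compound 3 (0.52 log units; beyond the scatter), a modest rise beyond the scatter on bringing in ethoxycarbonyl, so removing that group may undo much of that rise. Compound 1 also carries amino, but it has an acid where compound 4 keeps its ester, so compound 1 at 1.2 mg/kg is only a loose guide. A modest drop in this assay is therefore expected. The expected change is a 2.2-fold lower number from compound 3 to compound 4 (0.35 log units; beyond the scatter). The estimate for compound 4 is 0.45 mg/kg, with an expected range of 0.15 mg/kg to 1.4 mg/kg.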

Compound 4, dose for 50% inhibition: 0.5 mg/kg
Compound 4: middle estimate off by 1.1-fold (0.05 log units), on the low side, within the range that was stated.
By their numbers in this assay, from the lowest: compounds 2, 4, 3 and 1 (each within the scatter of the next, the first and the last beyond it).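

In this assay, amino at this place, para to an ethoxy group, cannot be separated from either earlier group: the result is a 2.0-fold lower number from compound 3 to compound 4 (0.30 log units; within the scatter) against ethoxycarbonyl and a 1.7-fold higher number from compound 2 to compound 4 (0.22 log units; within the scatter) against methoxy. With amino kept, the other end of the molecule does register, with ethyl in place of hydrogen on an oxygen next to a carbonyl group giving a 2.4-fold lower number from compound 1 to compound 4 (0.38 log units; beyond the scatter). No supporting measurement explains either result. Still open, as far as these compounds go, is whether hydroxyl or dimethylamino at this place would differ from amino, and whether a longer chain on the ester oxygen would shift the number further.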